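Swapping the Aromatic Ring on an Amide Carbonyl

The source may hold more compounds than are shown below. What is called first, only, known or untested is meant among the compounds shown, and "the series" means these compounds.

Of the compounds shown here, three built on one shared core have been tested in an assay on cells for displacement of a labelled ligand from adenosine receptor A1 (Homo sapiens), read by scintillation counting, with a stated time of 120 min, tested at 1 uM; a lower number here means less inhibition, a higher number more inhibition at the concentration tested (going by the name of the read-out). Compound 1 `COc1ccc(-c2cn3ccnc(N)c3n2)cc1` gives 1%, compound 2 `Nc1nccn2cc(-c3ccco3)nc12` gives 21%, and compound 3 `COc1ccc(C(=O)Nc2nccn3cc(-c4ccccc4)nc23)cc1` gives 1%. On these numbers compound 3 stands level with compound 1 at the digits shown, and the two together occupy the lowest place of the three; their gap lies within the usual scatter of repeated measurements. Compound 2 stands furthest from compound 3, and that gap lies beyond the scatter.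

Compound 4 `O=C(Nc1nccn2cc(-c3ccccc3)nc12)c1cccnc1` has not yet been measured. It differs from compound 3 in one place: pyridin-3-yl in place of 4-methoxyphenyl on a carbonyl carbon. Among the measured compounds shown here, no pair of measured compounds shows this exchange, so nothing measured tells how large its effect is. The expectation rests on compound 3 alone, which sits at 1% in this assay, and on the fact that the change keeps an amide carrying one six-membered aromatic ring on its carbonyl carbon. The step of a number 3 percentage points higher from compound 3 to compound 4 (within the scatter) is expected to be small, in no firm direction, and to stay within the scatter. Compound 4 is therefore estimated at 4%, with a range from 0% to 18%.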

Compound 4, a percentage reported as inhibition, at one concentration (the size of the read-out at that concentration, not a potency): 24%
Compound 4: the middle estimate sits 20 percentage points below what was measured; measured number above the stated range.
By their numbers in this assay, from the lowest: compounds 1 and 3 (each within the scatter of the next); then compounds 2 and 4 (each within the scatter of the next).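

In this assay, putting pyridin-3-yl in place of 4-methoxyphenyl on the carbonyl carbon gives a number 23 percentage points higher from compound 3 to compound 4 (beyond the scatter), so the group at this place can change the reading even when the amide stays and one six-membered aromatic ring remains on its carbonyl carbon. The exchange alters two things at once: the ring of carbon only gives way to a ring with one hetero atom, and the methoxy group is lost, so this single step cannot assign the rise to either change. Nothing measured on these compounds explains the step.

The compounds shown leave open whether the rise follows the ring nitrogen or the absence of the methoxy group, a question that a plain phenyl ring on the same carbonyl carbon could help to separate. They also leave open whether the place of the nitrogen in the ring matters, as a comparison with pyridin-2-yl or pyridin-4-yl would show, and whether a reading taken at a single concentration would carry over to a full measure of potency.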